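Shortening the Branched Chain on the Ether Oxygen

A few compounds are considered here, and "the series" means these few. Any claim that something is new, unique, unknown or untested is made for them only; others in the source may bear on it.

Compound 2 `CCCCCCOc1cccc(O)c1C(=O)/C=C/c1ccc(O)cc1` is known in a functional assay on PC-3 cells (Homo sapiens) for antiproliferative activity, read by sulforhodamine B assay (on this read-out lower numbers stand for stronger inhibition of growth and higher numbers for weaker inhibition of growth), only as a limit of > 30000 nM. Compound 3 `CC(C)=CCOc1cccc(O)c1C(=O)/C=C/c1ccc(O)cc1` likewise shows only the limit > 30000 nM in this assay. Compound 1 `CC(C)CCCOc1cccc(O)c1C(=O)/C=C/c1ccc(O)cc1` gives a measured number, 3600 nM, in this assay. The step of an at least 8.3-fold higher number from compound 1 to compound 2 (0.92 log units; beyond the scatter) and the step of an at least 8.3-fold higher number from compound 1 to compound 3 (0.92 log units; beyond the scatter) both end at the limit of > 30000 nM in this assay, at which 2 of the 3 values shown sit, so branching of the chain appears to matter for growth inhibition within these three compounds. Compound 4 `CC(C)COc1cccc(O)c1C(=O)/C=C/c1ccc(O)cc1` differs from compound 2 by isopropyl in place of pentyl on a saturated chain carbon bound to an oxygen on an aromatic ring. Because compound 1, which also carries a branched chain, gives 3600 nM, compound 4 is expected to regain measurable inhibition, estimated at 6000 nM with a range of 1500 nM to 30000 nM. The expected step is therefore an at least 5.0-fold lower number from compound 2 to compound 4 (0.69 log units; beyond the scatter).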

Compound 4, concentration for 50% growth inhibition: 2970 nM
Compound 4: the middle estimate sits 2.0-fold (0.31 log units) above what was measured; the measured number falls inside the stated range.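

In this assay, the isobutoxy chain of compound 4 brings a clear gain, with an at least 10-fold lower number from compound 2 to compound 4 (1.00 log units; beyond the scatter) and an at least 10-fold lower number from compound 3 to compound 4 (1.00 log units; beyond the scatter). The chain can also be shortened without a real change, with a 1.2-fold lower number from compound 1 to compound 4 (0.08 log units; within the scatter), so two saturated branched chains of different length both give measurable values, while compound 3 shows that a branch alone is not enough. Compounds 2 and 3 are known only as a limit: the limit of > 30000 nM in this assay, at which 2 of the 4 values shown sit. From the compounds shown here alone, whether a chain ending in an amine or a carboxylic acid would be tolerated on this oxygen remains open.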